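The source may report more compounds than this note shows. Statements on the series, on what has been measured and on what is new or still open speak of the compounds shown alone.

Compound 1, `ClCc1cccc(Cn2cnc3c(Cl)nc(Cl)nc32)c1`, gives 4360 nM in a functional assay on HOP-62 cells (Homo sapiens) for cytotoxicity, read by sulforhodamine B assay, with a stated time of 48 h; a lower number here means a stronger inhibitor of growth, a higher number a weaker inhibitor of growth.
Compound 2, `ClCc1cccc(Cn2cnc3nc(Cl)nc(Cl)c32)c1`, gives 3630 nM in this assay.
Compound 3, `ClCc1ccccc1Cn1cnc2nc(Cl)nc(Cl)c21`, gives 5490 nM in this assay.

The three measured compounds are built from the same parts joined in different arrangements, and their numbers sit close together. Compound 1 has the second highest of the three numbers: compound 2 gives a slightly lower number and compound 3 a slightly higher one, but both gaps are within the usual scatter of repeated measurements, so no order among the three can be claimed and none of them can be called the most or least potent.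

Compound 4, `ClCc1cccc(Cn2cnc3c(Cl)ncnc32)c1`, has not yet been measured. It differs from compound 1 in a single place: hydrogen in place of chloro on an aromatic carbon. Among the compounds with values here, no pair of measured compounds shows this kind of change, so there is no direct guide to its size. A small loss of potency, at most a modest step upward in the number and perhaps not beyond the scatter, is the expectation here. The estimated step from compound 1 to compound 4 is a 1.6-fold higher number from compound 1 to compound 4 (0.21 log units; within the scatter). Compound 4 is therefore expected to give about 7000 nM, in a range from 3000 nM to 18000 nM.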

Compound 4, concentration for total growth inhibition: 5120 nM
Compound 4: middle estimate off by 1.4-fold (0.14 log units), on the high side; low and high end bracket the measured number.
By their numbers in this assay, from the lowest: compounds 2, 1, 4 and 3 (each within the scatter of the next).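

In this assay, putting hydrogen in place of chloro on the aromatic carbon between two ring nitrogen atoms gives a 1.2-fold higher number from compound 1 to compound 4 (0.07 log units; within the scatter). Within the data shown here, this is the first direct comparison in which only one place differs, and it shows that this chloro can be lost without a difference that can be claimed in this growth read-out. The result therefore gives no sign that growth inhibition at this level depends on a chloro group at this position, though it rests on a single pair of compounds, and nothing shown here offers an explanation for it.

On these data alone, it remains open whether a larger group on the same carbon, such as an amine or a methoxy group, would also leave the number within the scatter or would move it clearly in either direction. As far as these compounds go, the contribution of the remaining chloro group and of the chloromethyl group, both still present in compound 4, also stays open, and so does whether this result would hold in the other arrangements of the same parts seen in compound 2 and compound 3.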